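Replacing the hydroxyhexyl tail with a methylsulfonylpiperazine

A few compounds are considered here, and "the series" means these few. Any claim that something is new, unique, unknown or untested is made for them only; others in the source may bear on it.

Measured compounds:
compound 1 `COc1cc(N)c(Cl)cc1C(=O)NC1CCN(CCCCCCCCO)CC1` — > 100%
compound 2 `COc1cc(N)c(Cl)cc1C(=O)NC1CCN(CCCCCCCCN2CCCCC2)CC1` — > 100%

In a functional assay on HEK293 cells for activation of 5-hydroxytryptamine receptor 4 (Homo sapiens), read by cAMP accumulation (on this read-out higher numbers stand for larger maximal responses and lower numbers for smaller maximal responses), compound 1 gives > 100%, which is a limit of the assay and not a number. Compound 2 likewise returns a limit in this assay, > 100%. The step that the two limits leave unreadable from compound 1 to compound 2 cannot be sized, since both values sit at the limit of > 100% in this assay, at which 2 of the 2 values shown sit. Compound 3 `COc1cc(N)c(Cl)cc1C(=O)NC1CCN(CCN2CCN(S(C)(=O)=O)CC2)CC1` differs from compound 1 by 4-(methylsulfonyl)piperazin-1-yl in place of 6-hydroxyhexyl on a saturated chain carbon, two bonds along the chain from an amine nitrogen in a ring. Among the compounds with values here, no measured step bears on this change, so no direction beyond the scatter can be expected. Compound 3 is estimated to reach 100%, within 80% to 115%, an expected step of a number no higher from compound 1 to compound 3 (the limit leaves the size open).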

Compound 3, intrinsic activity: the largest response reached, in percent of the reference agonist's: 97%
For compound 3 the middle estimate is 3 percentage points above the measured one; measured number inside the range.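

In this assay the change to 4-(methylsulfonyl)piperazin-1-yl gives a number at least 3 percentage points lower from compound 1 to compound 3 (that floor lies within the scatter). From the compounds shown here alone, compound 1 stands at > 100%, which is a limit and not a number, so this step has only a floor and its true size stays open. Compound 3 is the only compound shown with a value that sits off the limit: the limit of > 100% in this assay, at which 2 of the 3 values shown sit.

The compounds shown leave open whether the methylsulfonyl group itself matters, which a piperazine carrying an acetyl group or a free ring amine would test. They also leave open how a longer chain between the two rings would read.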